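Replacing thiophen-2-yl with tert-butyl: compound 1 to compound 4

This account rests on a few compounds, and the source may have more. Where it says the series, first, only, none or still open, it means among the compounds named here.

In a functional assay on MCF7 cells (Homo sapiens) for inhibition, read by MTT assay, with a stated time of 72 h (on this read-out higher numbers stand for weaker inhibition and lower numbers for stronger inhibition), compound 1 (`Cc1cc(Nc2cc(-c3cccs3)[nH]n2)n2nc(SCc3ccc(Br)cc3)nc2n1`) gives 5370 nM and compound 2 (`Cc1cc(Nc2cc(-c3ccccc3)[nH]n2)n2nc(SCc3ccc([N+](=O)[O-])cc3)nc2n1`) gives 5060 nM as its value. These two readings lie within the usual scatter of each other, so compound 1 stands level with compound 2. For compound 3 (`Cc1cc(Nc2cc(-c3ccccc3)[nH]n2)n2nc(SCC3CCCCC3)nc2n1`) the assay gives only a limit (> 50000 nM).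

Compound 4 (`Cc1cc(Nc2cc(C(C)(C)C)[nH]n2)n2nc(SCc3ccc(Br)cc3)nc2n1`) keeps the core of compound 1 and carries tert-butyl in place of thiophen-2-yl on an aromatic carbon. Here an aromatic ring leaves and a group without a ring enters.

For the measured compounds named here, only one measured step offers any guidance (an at least 9.8-fold higher number from compound 2 to compound 3 (0.99 log units; beyond the scatter)). It lies beyond the scatter and also removes an aromatic ring, with cyclohexyl in place of 4-nitrophenyl, but on a saturated chain carbon bound to a sulfur. That is a different place from the present change, and the step carries a limit, so it supports a direction only weakly and gives no firm size.

A moderate loss is therefore expected, smaller than that single precedent, and the estimate is a 2.4-fold higher number from compound 1 to compound 4 (0.38 log units; beyond the scatter) in this assay towards weaker inhibition. The expected value for compound 4 is 13000 nM (estimated range 4500 nM to 40000 nM).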

Compound 4, half-maximal inhibitory concentration: 7290 nM
Estimate against measurement, compound 4: 1.8-fold (0.25 log units) above; low and high end bracket the measured number.
By their numbers in this assay, from the lowest: compounds 2, 1 and 4 (each within the scatter of the next). At a limit, above all of these: compound 3.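

In this assay, tert-butyl in place of thiophen-2-yl on an aromatic carbon of the five-membered aromatic ring with 2 nitrogen gives a 1.4-fold higher number from compound 1 to compound 4 (0.13 log units; within the scatter), so in this pair the aromatic ring at this position can be exchanged for a group without a ring with no step beyond the scatter. The removal of an aromatic ring therefore has no single reading across the series: on a saturated chain carbon bound to a sulfur, the exchange of 4-nitrophenyl for cyclohexyl gives an at least 9.8-fold higher number from compound 2 to compound 3 (0.99 log units; beyond the scatter), and that step ends at a limit of the assay. Nothing measured on the compounds at hand speaks to why the two groups read level at this position.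

Open, as far as these compounds go, is whether an amine, a carboxylic acid or a longer chain on this same aromatic carbon would also stay within the scatter of compound 1. Also open, from the compounds shown here alone, is whether tert-butyl and thiophen-2-yl would still read level with cyclohexyl or 4-nitrophenyl on the saturated chain carbon bound to a sulfur, in place of the group carried there by compound 1 and compound 4.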